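The source may report more compounds than this note shows. Statements on the series, on what has been measured and on what is new or still open speak of the compounds shown alone.

Of the compounds shown here, three built on one shared core have been measured so far. In a functional assay on MCF7 cells (Homo sapiens) for antiproliferative activity, read by MTT assay, with a stated time of 48 h (on this read-out lower numbers stand for stronger inhibition and higher numbers for weaker inhibition), compound 1 `O=C(/C=C/c1cccc(NC(=O)c2ccccc2Cl)c1)c1nc2ccccc2[nH]1` gives 4570 nM, compound 2 `O=C(/C=C/c1cccc(NC(=O)c2ccccc2Br)c1)c1nc2ccccc2[nH]1` gives 4520 nM, and compound 3 `O=C(Nc1cccc(/C=C/C(=O)c2nc3ccccc3[nH]2)c1)c1cccc(Br)c1` gives 5210 nM. Compound 3 carries the highest of the three numbers, yet its gaps to the others, a 1.1-fold higher number from compound 1 to compound 3 (0.06 log units; within the scatter) and a 1.2-fold higher number from compound 2 to compound 3 (0.06 log units; within the scatter), both fall within the usual scatter, as does a 1.0-fold lower number from compound 1 to compound 2 (0.00 log units; within the scatter). Compound 4 `Cc1ccccc1C(=O)Nc1cccc(/C=C/C(=O)c2nc3ccccc3[nH]2)c1` has not been measured. It differs from compound 3 in one place: 2-methylphenyl in place of 3-bromophenyl on a carbonyl carbon. The two measured changes at that same carbonyl carbon, a 1.1-fold higher number from compound 1 to compound 3 (0.06 log units; within the scatter) and a 1.2-fold higher number from compound 2 to compound 3 (0.06 log units; within the scatter), moved the numbers very little, so no step beyond the scatter is expected in this assay here either. The expected step is a 1.0-fold lower number from compound 3 to compound 4 (0.02 log units; within the scatter). Compound 4 is therefore estimated at 5000 nM, with a range from 2500 nM to 10000 nM.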

Compound 4, half-maximal inhibitory concentration: 5870 nM
For compound 4 the middle estimate is 1.2-fold (0.07 log units) below the measured one, and the stated range covers the measured number.
By their numbers in this assay, from the lowest: compounds 2, 1, 3 and 4 (each within the scatter of the next).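

In this assay methyl in place of bromo gives a 1.3-fold higher number from compound 2 to compound 4 (0.11 log units; within the scatter) and methyl in place of chloro gives a 1.3-fold higher number from compound 1 to compound 4 (0.11 log units; within the scatter) while 2-methylphenyl in place of 3-bromophenyl gives a 1.1-fold higher number from compound 3 to compound 4 (0.05 log units; within the scatter) as its third step. So a ring carrying no halogen at all can now be placed on this carbonyl carbon, and every step still stays within the scatter. No measurement here bears on why the numbers stay so close. The compounds shown leave open whether an amine, a carboxylic acid or a longer chain on this ring would move the number beyond the scatter.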